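The source may report more compounds than this note shows. Statements on the series, on what has been measured and on what is new or still open speak of the compounds shown alone.

In an assay on membranes from HEK293 cells for displacement of a labelled ligand from adenosine receptor A2b (Homo sapiens), read by scintillation counting, with a stated time of 30 min, tested at 1 uM (on this read-out higher numbers stand for more inhibition at the one concentration tested (going by the name of the read-out) and lower numbers for less inhibition), compound 1 `COC(=O)C1=C(C)N(C)C(=O)NC1c1ccsc1` gives 26%, and compound 2 `CCOC(=O)C1=C(C)N(C)C(=O)NC1c1ccsc1` gives 53%. Among the measured compounds shown here, compound 2 thus stands highest of the two numbers measured so far, with compound 1 as its only comparator. For the measured compounds named here, the single measured step, a number 27 percentage points higher from compound 1 to compound 2 (beyond the scatter), introduced a methyl in place of hydrogen on a saturated chain carbon bound to an oxygen next to a carbonyl group. Compound 3 `CC1=C(C(=O)OCC(C)C)C(c2ccsc2)NC(=O)N1C` has not yet been measured; it differs from compound 2 in one place: isopropyl in place of methyl on a saturated chain carbon bound to an oxygen next to a carbonyl group. The step between compound 1 and compound 2 is the only measured one that bears on this change, since it grows the same chain at the same place, and it was modest. A further gain in this assay is therefore expected, though smaller and less certain, so that the step is estimated as a number 7 percentage points higher from compound 2 to compound 3 (within the scatter). Compound 3 is expected to give 60%, with a range from 35% to 85%.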

Compound 3, a percentage reported as inhibition, at one concentration (the size of the read-out at that concentration, not a potency): 1%
Beside the measured number, compound 3's estimate is 59 percentage points above it; measured number outside the range, below it.
By their numbers in this assay, from the lowest: compound 3; then compound 1; then compound 2.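

In this assay, growth of the chain at this place does not keep raising the number: after a number 27 percentage points higher from compound 1 to compound 2 (beyond the scatter), exchanging methyl for isopropyl gives a number 52 percentage points lower from compound 2 to compound 3 (beyond the scatter). The isopropyl change also carries the series past its starting point, since isopropyl in place of hydrogen gives a number 25 percentage points lower from compound 1 to compound 3 (beyond the scatter), which leaves the ethoxycarbonyl of compound 2 highest and the isobutoxycarbonyl of compound 3 lowest of these three. Nothing available accounts for this reversal.

On these data alone, whether the fall goes with the branch or with the length of the chain stays open, and a straight propyl or butyl chain at this place would tell the two apart. Also open, as far as these compounds go, is how a benzyl group or a methoxyethyl chain would read here.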